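The source may hold more compounds than are shown below. What is called first, only, known or untested is meant among the compounds shown, and "the series" means these compounds.

In an assay on isolated protein for inhibition of MAP kinase-activated protein kinase 2 (Homo sapiens), read by HTRF, tested at 10 uM (a lower number here means less inhibition, a higher number more inhibition at the concentration tested (going by the name of the read-out)), compound 2 `COC[C@@H]1CCCN1C(=O)[C@@H]1CCCN1c1nccc(Nc2ccccc2)n1` gives 1%. Compound 1 `CN(CCCn1ccnc1)C(=O)[C@@H]1CCCN1c1nccc(Nc2ccccc2)n1` gives 2% in this assay, and compound 3 `Cc1cccc(Nc2nccc3c2CN(C(=O)c2cc(C)n(C)c2C)CC3)c1` gives 0%; all three numbers lie within the scatter of one another, so none can be set apart, and each shows very little inhibition at the concentration tested. Compound 4 `CN(C)CC(C)(C)CNC(=O)[C@@H]1CCCN1c1nccc(Nc2ccccc2)n1` differs from compound 2 in a single place: (2-((dimethylamino)methyl)-2-methylpropyl)amino in place of 2-(methoxymethyl)pyrrolidin-1-yl on a carbonyl carbon. For the measured compounds named here, the only measured step that bears on this change also swaps the group on the same carbonyl carbon, and it was a number 1 percentage points lower from compound 1 to compound 2 (within the scatter). A further swap of that kind is therefore expected to produce no step beyond the scatter, namely a number 1 percentage points higher from compound 2 to compound 4 (within the scatter). Compound 4 is estimated at 2%, with a likely range from -7% to 12%.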

Compound 4, a percentage reported as inhibition, at one concentration (the size of the read-out at that concentration, not a potency): 4%
Compound 4: the middle estimate sits 2 percentage points below what was measured, within the range that was stated.
By their numbers in this assay, from the lowest: compounds 3, 2, 1 and 4 (each within the scatter of the next).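

Even a group with no ring, unlike the 2-(methoxymethyl)pyrrolidin-1-yl, does not set the compound apart on this carbonyl carbon in this assay: the readings show a number 3 percentage points higher from compound 2 to compound 4 (within the scatter) and a number 2 percentage points higher from compound 1 to compound 4 (within the scatter). Three different groups at this place now leave inhibition very low, and no measurement at hand offers a reason for this. Going by these compounds, whether a carboxylic acid or a longer chain on this carbonyl carbon would lift inhibition clear of the scatter remains open. So does whether any group here matters at all while readings stay this low.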